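Swapping a Bromophenyl Amide for a Methylphenyl Amide

The source may report more compounds than this note shows. Statements on the series, on what has been measured and on what is new or still open speak of the compounds shown alone.

Three compounds built on the same core differ only in the aryl group attached to the amide carbonyl. Compound 1 `O=C(Nc1cccc(/C=C/C(=O)c2nc3ccccc3[nH]2)c1)c1ccccc1` carries a plain phenyl there; in a functional assay on 143B cells (Homo sapiens) for antiproliferative activity, read by MTT assay, with a stated time of 48 h (a higher number here means a weaker inhibitor, a lower number a stronger inhibitor), compound 1 gives 8340 nM. Compound 2 `O=C(/C=C/c1cccc(NC(=O)c2ccccc2Br)c1)c1nc2ccccc2[nH]1` carries a 2-bromophenyl, and in this assay compound 2 gives 6050 nM. Compound 3 `O=C(Nc1cccc(/C=C/C(=O)c2nc3ccccc3[nH]2)c1)c1cccc(Br)c1` carries a 3-bromophenyl, and in this assay compound 3 gives 4620 nM. Compound 3 has the lowest of the three numbers, but the gaps are slight: a 1.8-fold lower number from compound 1 to compound 3 (0.26 log units; within the scatter), a 1.4-fold lower number from compound 1 to compound 2 (0.14 log units; within the scatter), and a 1.3-fold lower number from compound 2 to compound 3 (0.12 log units; within the scatter). Each of these lies within the scatter of repeated measurements, so the three compounds cannot be ranked with confidence.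

Compound 4 `Cc1ccccc1C(=O)Nc1cccc(/C=C/C(=O)c2nc3ccccc3[nH]2)c1` has not yet been measured. It differs from compound 3 by 2-methylphenyl in place of 3-bromophenyl on a carbonyl carbon. All three measured steps bear on this change, since each alters the same aryl group on the carbonyl carbon, and each stayed within the scatter. Within the data shown here, a methyl group has not appeared among the measured compounds, so there is no direct precedent for it. The expected step is accordingly small: a 1.3-fold higher number from compound 3 to compound 4 (0.11 log units; within the scatter). Compound 4 is estimated at 6000 nM in this assay, within a range from 2500 nM to 14000 nM.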

Compound 4, half-maximal inhibitory concentration: 8290 nM
Beside the measured number, compound 4's estimate is 1.4-fold (0.14 log units) below it, and the stated range covers the measured number.
By their numbers in this assay, from the lowest: compounds 3, 2, 4 and 1 (each within the scatter of the next).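

Among these compounds, compound 4 puts a methyl group on the aryl ring for the first time, and the change adds only more small steps: a 1.8-fold higher number from compound 3 to compound 4 (0.25 log units; within the scatter), a 1.4-fold higher number from compound 2 to compound 4 (0.14 log units; within the scatter) and a 1.0-fold lower number from compound 1 to compound 4 (0.00 log units; within the scatter). With this result, all four aryl groups on the carbonyl carbon (phenyl, 2-bromophenyl, 3-bromophenyl and 2-methylphenyl) lie within the scatter of one another in this assay, so neither bromo nor methyl in place of hydrogen gives a difference that can be read, and the same holds for methyl in place of bromo. No supporting measurement is available to explain this flat picture.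

Going by these compounds, it remains open whether a group of a different kind on this aryl ring, such as an amine, a carboxylic acid or a longer chain such as a butyl group, would move the number beyond the scatter. All four compounds also share the same core and were read in the same cell assay, so the effect of changes elsewhere in the core, and how these aryl groups behave in other cells, cannot be told from them.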